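Trading a methyl for hydrogen on a four-membered ring

This account rests on a few compounds, and the source may have more. Where it says the series, first, only, none or still open, it means among the compounds named here.

In an ADME assay on liver for metabolic stability, with Liver microsome (Rattus norvegicus) as the target, read by LC-MS, using microsomes, with a stated time of 5 h (a higher number here means faster removal of the compound, a lower number slower removal), compound 3 `C[C@]1(O)C[C@@](c2cccc(C(F)(F)F)c2)([C@H](O)c2ccccn2)C1` gives 317 mL/min/kg as its reading. In the same test compound 1 `O[C@H](c1ccccn1)[C@]1(c2cccc(OC(F)(F)F)c2)C[C@@H](O)C1` gives 217 mL/min/kg and compound 2 `O[C@H](c1ccccn1)[C@]1(c2cccc(C(F)(F)F)c2)C[C@H](O)C1` gives 183 mL/min/kg as theirs. All three readings lie within the usual scatter of one another, so these numbers do not set compound 3 apart from the other two.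

Compound 4 `O[C@H](c1ccccn1)[C@]1(c2cccc(C(F)(F)F)c2)C[C@@H](O)C1` is compound 3 with a single edit hydrogen in place of methyl on a saturated ring carbon and in words this is hydrogen in place of methyl on a saturated ring carbon. Within the data shown here, no pair of measured compounds shows this change on its own, so no direct step is available to lean on. Among the measured compounds shown here, the only guide is indirect. That ring carbon bears hydrogen in compound 1 with 217 mL/min/kg and in compound 2 with 183 mL/min/kg as readings, and it bears methyl in compound 3 with 317 mL/min/kg as its reading. With so few compounds, only a modest downward move that stays within the scatter seems reasonable in this assay here. The expected change is a 1.6-fold lower number from compound 3 to compound 4 (0.20 log units; within the scatter) and no more than that. For compound 4 the estimate is 200 mL/min/kg with an expected range from 120 mL/min/kg to 320 mL/min/kg as its limits.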

Compound 4, clearance: 100 mL/min/kg
Estimate against measurement, compound 4: 2.0-fold (0.30 log units) above, outside the stated range (below it).
By their numbers in this assay, from the lowest: compounds 4, 2, 1 and 3 (each within the scatter of the next, the first and the last beyond it).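

Among these compounds, this is the first direct reading of the change at this position: with the rest of the molecule the same, hydrogen in place of methyl on the saturated ring carbon of the four-membered ring gives, in this assay, a 3.2-fold lower number from compound 3 to compound 4 (0.50 log units; beyond the scatter). Elsewhere on the molecule, trifluoromethyl in place of trifluoromethoxy on an aromatic carbon gives a 2.2-fold lower number from compound 1 to compound 4 (0.34 log units; beyond the scatter), so in this one pair the aromatic substituent also moves the reading by more than the scatter. Hydrogen on that ring carbon is shared with compound 2, and a 1.8-fold lower number from compound 2 to compound 4 (0.26 log units; within the scatter) leaves the two readings within the scatter of each other, a comparison in which no atom or bond changes: the fact that compounds 2 and 4 differ only in the configuration as drawn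

The compounds shown carry only hydrogen or methyl on this ring carbon, so it remains open how a longer chain such as ethyl, or an amine, would read there. On these data alone, it is also open whether the methyl step would be of similar size with trifluoromethoxy on the aromatic carbon or with the configuration drawn in compound 2.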